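From ethyl to cyclopentyl on compound 2

A few compounds are considered here, and "the series" means these few. Any claim that something is new, unique, unknown or untested is made for them only; others in the source may bear on it.

- Compound 1 `CCC(=O)c1cc(-c2ccc(Cl)cc2)n(-c2ccc(S(C)(=O)=O)cc2)c1C` gives 4800 nM in the measurement below
- Compound 2 `CCCC(=O)c1cc(-c2ccc(S(N)(=O)=O)cc2)n(-c2ccc(Cl)cc2)n1` gives 25800 nM in the measurement below

Both compounds were measured in a physicochemical assay for solubility, read by HPLC, in phosphate buffer, measured as kinetic solubility, at pH 7.4 (a lower number here means a less soluble compound, a higher number a more soluble compound), and these two numbers are all that is known so far. Compound 2 stands higher of the two with 25800 nM on this scale, and the gap down to compound 1 lies beyond the usual scatter. Among the measured compounds shown here, no pair of measured compounds differs in one place only, so the data hold no direct guide to a single change.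

Compound 3 `NS(=O)(=O)c1ccc(-c2cc(C(=O)CC3CCCC3)nn2-c2ccc(Cl)cc2)cc1` has not yet been measured. It departs from compound 2 by one change (cyclopentyl in place of ethyl on a saturated chain carbon bound to a carbonyl carbon), which is cyclopentyl in place of ethyl on a saturated chain carbon bound to a carbonyl carbon.

For the measured compounds named here, the expected change in this assay is downward and beyond the scatter, estimated as a 4.3-fold lower number from compound 2 to compound 3 (0.63 log units; beyond the scatter) in size, though this remains a judgement that no measured pair tests. For compound 3 the expected value is 6000 nM, with an estimated range from 1800 nM to 16000 nM when the measurement arrives.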

Compound 3, solubility: 2600 nM
Compound 3: the middle estimate sits 2.3-fold (0.36 log units) above what was measured, within the range that was stated.
By their numbers in this assay, from the lowest: compounds 3 and 1 (each within the scatter of the next); then compound 2.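

Cyclopentyl in place of ethyl on a saturated chain carbon bound to a carbonyl carbon gives a 9.9-fold lower number from compound 2 to compound 3 (1.00 log units; beyond the scatter) in this assay and this is the first step in the series that changes one place only. It shows that this position is not silent in this measurement: the group here alone moves the read-out beyond the usual scatter, with the rest of compound 2 left untouched. The two groups differ only in carbon count and in the five-membered non-aromatic ring, as both carry 0 hydrogen-bond donors and 0 hydrogen-bond acceptors and neither has a net charge, and nothing measured explains the drop.

The compounds shown leave open whether the ring itself or simply the larger number of carbons goes with the lower number, a question that an open chain such as pentyl at the same place would separate. They also leave open how an amine or a carboxylic acid on this chain would read, and whether the same exchange would give a similar step on the core of compound 1.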